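A few compounds are considered here, and "the series" means these few. Any claim that something is new, unique, unknown or untested is made for them only; others in the source may bear on it.

Measured in an ADME assay on the whole organism (Canis lupus familiaris, strain Beagle) for pharmacokinetics (on this read-out higher numbers stand for higher oral bioavailability and lower numbers for lower oral bioavailability), the three known compounds read as follows:

Compound 1, `CCn1c(-c2ccc(C(F)(F)F)nc2)nc2c(O[C@H]3CCN(C(=O)c4cocn4)C3)ncnc21`: 100%
Compound 2, `CCn1c(-c2ccc(C(F)(F)F)nc2)nc2c(O[C@H]3CCN(C(=O)N4CC(OC)C4)C3)ncnc21`: 100%
Compound 3, `CCn1c(-c2cnc(C)nc2)nc2c(N[C@H]3CCN(C(=O)[C@H]4C[C@@H](OC)C4)C3)ncnc21`: 85%

Compound 3 stands lowest of the three in this assay; its values against compound 1 and against compound 2 each lie beyond the usual scatter of this kind of measurement, while compound 1 and compound 2 are indistinguishable from each other.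

The unmeasured compound 4, `CCn1c(-c2cnc(C)nc2)nc2c(N[C@H]3CCN(C(=O)C4CC4)C3)ncnc21`, differs from compound 3 in one place only: cyclopropyl in place of 3-methoxycyclobutyl on a carbonyl carbon. The carbonyl carbon itself and the ring-bound amide-type nitrogen beside it stay as they are.

Going by the values given here, only one measured step touches the same spot. Among the compounds with values here, changing the group on that carbonyl carbon from compound 1 to compound 2 gave no change at the digits printed from compound 1 to compound 2 (within the scatter), although those two compounds sit on a core that differs from the one shared by compound 3 and compound 4. That single precedent suggests that swapping the group on the carbonyl carbon leaves oral bioavailability where it is, so no step beyond the scatter is expected in this assay for compound 4, that is no change at the digits printed from compound 3 to compound 4 (within the scatter). On that basis compound 4 is estimated at 85%, within a range from 65% to 100%.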

Compound 4, oral bioavailability: 95%
Compound 4: middle estimate off by 10 percentage points, on the low side; measured number inside the range.
By their numbers in this assay, from the lowest: compounds 3, 4, 1 and 2 (each within the scatter of the next, the first and the last beyond it).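

The step at this position on the core shared by compound 3 and compound 4, measured in this assay, reads a number 10 percentage points higher from compound 3 to compound 4 (within the scatter). Going by these compounds alone, the only earlier step at this carbonyl carbon, no change at the digits printed from compound 1 to compound 2 (within the scatter), came from a different core and exchanged 1,3-oxazol-4-yl for 3-methoxyazetidin-1-yl, so the new pair adds a second core and a different kind of exchange: 3-methoxycyclobutyl gives way to the smaller cyclopropyl, which has no oxygen, no hydrogen-bond acceptor and no defined stereocentres, and the number still stays within the scatter, which means that neither the methoxy oxygen nor the two stereocentres of the group that leaves is needed to hold the read-out in this pair. No measurement shown here explains this outcome.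

All the groups shown on this carbonyl carbon are uncharged and ring-based, so it remains open whether a carboxylic acid, a primary amine or a longer chain such as n-hexyl would be accommodated equally well. Within the data shown here, with only two steps at this spot, each on its own core, it is also open whether either exchange would give the same outcome on the other core.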